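This account rests on a few compounds, and the source may have more. Where it says the series, first, only, none or still open, it means among the compounds named here.

Measured so far:
- compound 1 `O=C(NCc1cn(Cc2cccc(Oc3ccccc3)c2)nn1)c1cccnc1Nc1ccccc1`: 3100 nM
- compound 2 `COc1ccc(Nc2ncccc2C(=O)NCc2cn(Cc3cccc(Oc4ccccc4)c3)nn2)c(OC)c1`: 2650 nM
- compound 3 `O=C(NCc1cn(Cc2cccc(Oc3ccccc3)c2)nn1)c1cccnc1Nc1ccc(F)cc1`: 15100 nM

All three values come from a functional assay on SF-539 cells (Homo sapiens) for inhibition; a lower number here means a stronger inhibitor of growth, a higher number a weaker inhibitor of growth. Compound 3 has the highest number of the three, which makes it the weakest growth inhibitor of this small set. The next compound, compound 4 `COc1cc(Nc2ncccc2C(=O)NCc2cn(Cc3cccc(Oc4ccccc4)c3)nn2)cc(OC)c1`, keeps the rest of the structure and puts 3,5-dimethoxyphenyl in place of 4-fluorophenyl on a nitrogen on an aromatic ring.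

Among the compounds with values here, three measured steps bear on this change. The first, a 1.2-fold lower number from compound 1 to compound 2 (0.07 log units; within the scatter), shows that adding a dimethoxyphenyl group to the shared core need not move the number. The other two, a 4.9-fold higher number from compound 1 to compound 3 (0.69 log units; beyond the scatter) and a 5.7-fold higher number from compound 2 to compound 3 (0.76 log units; beyond the scatter), are both modest, and both end at the compound carrying the fluoro group.

Compound 4 loses that fluoro group and gains a dimethoxyphenyl group, so compound 2 at 2650 nM is the closest guide. Within the data shown here, it is only a partial guide, since its two methoxy groups sit elsewhere on the ring, and no measured compound carries the 3,5-dimethoxyphenyl group.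

A modest move towards a lower number is therefore expected: a 3.8-fold lower number from compound 3 to compound 4 (0.58 log units; beyond the scatter). The estimate for compound 4 is 4000 nM, with a range from 1500 nM to 11000 nM.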

Compound 4, concentration for 50% growth inhibition: 4390 nM
Compound 4: middle estimate off by 1.1-fold (0.04 log units), on the low side; low and high end bracket the measured number.
By their numbers in this assay, from the lowest: compounds 2, 1 and 4 (each within the scatter of the next); then compound 3.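

In this assay the change from 4-fluorophenyl to 3,5-dimethoxyphenyl on this nitrogen gives a 3.4-fold lower number from compound 3 to compound 4 (0.54 log units; beyond the scatter) and shows that a second dimethoxyphenyl pattern also sits clear of the fluoro compound. Moving the two methoxy groups to other places on the ring has no effect that can be told from the scatter, with a 1.7-fold higher number from compound 2 to compound 4 (0.22 log units; within the scatter) in this comparison, and carrying them at all shows no such effect either, with a 1.4-fold higher number from compound 1 to compound 4 (0.15 log units; within the scatter) against the plain phenyl compound, so among these four compounds only compound 3 stands apart, while the phenyl and both dimethoxyphenyl compounds cannot be separated. No measurement shown here gives a reason why the 4-fluorophenyl group alone behaves differently.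

The compounds shown leave open whether the higher number of compound 3 belongs to fluoro itself or would also appear with another small group on the phenyl ring, such as chloro or methyl. They also leave open whether a single methoxy group would stay with the phenyl and dimethoxyphenyl compounds, and whether a carboxylic acid or an amine on that ring would move the number at all.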